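The source may report more compounds than this note shows. Statements on the series, on what has been measured and on what is new or still open speak of the compounds shown alone.

In a functional assay on DLD-1 cells (Homo sapiens) for cytotoxicity, read by MTT assay, with a stated time of 96 h (a higher number here means a weaker inhibitor, a lower number a stronger inhibitor), compound 2 `CCCOCc1cc(O)c(O)c(Br)c1` gives 26300 nM, and compound 1 `O=Cc1cc(O)c(O)c(Br)c1Br` gives 30900 nM; these two numbers lie within the scatter of each other, so neither compound can be set apart from the other. Compound 3 `CCCOCc1cc(O)c(O)c(Br)c1Br` differs from compound 2 in one place, (bromo in place of hydrogen on an aromatic carbon). Among the compounds with values here, no step between measured compounds is available to gauge this change, and it is expected to bring no shift beyond the scatter in this assay in either direction. Compound 3 is therefore estimated at 25000 nM, with a range from 10000 nM to 60000 nM, the expected step of a 1.1-fold lower number from compound 2 to compound 3 (0.02 log units; within the scatter) remaining within the scatter.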

Compound 3, half-maximal inhibitory concentration: 12400 nM
Beside the measured number, compound 3's estimate is 2.0-fold (0.30 log units) above it; the measured number falls inside the stated range.
By their numbers in this assay, from the lowest: compound 3; then compounds 2 and 1 (each within the scatter of the next).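

In this assay, within the data shown here, bromo in place of hydrogen on the aromatic carbon ortho to a bromo group and ortho to a propoxymethyl group gives a 2.1-fold lower number from compound 2 to compound 3 (0.33 log units; beyond the scatter) as the first readable step at this position, and it lies beyond the scatter. With both bromo groups present, propoxymethyl in place of formyl gives a 2.5-fold lower number from compound 1 to compound 3 (0.40 log units; beyond the scatter) as a second modest step, so a change at either place moves the number. No measurement shown explains either step. The compounds shown leave open whether chloro in place of this bromo would give a similar step, and whether a longer chain in place of propoxymethyl would shift the number further.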